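A few compounds are considered here, and "the series" means these few. Any claim that something is new, unique, unknown or untested is made for them only; others in the source may bear on it.

Four compounds share one core and differ at the amide. Compound 1 `CC(C)c1cc(C(=O)N2CCc3c(sc(NCc4ccccc4)c3C#N)C2)[nH]n1` gives 43200 nM in a functional assay on Chem-3 cells for antagonist activity at metabotropic glutamate receptor 1 (Homo sapiens), read by fluorescence and calcium flux; a lower number here means a stronger inhibitor, a higher number a weaker inhibitor; compound 2 `N#Cc1c(NCc2ccccc2)sc2c1CCN(C(=O)c1ccn[nH]1)C2` gives 1090 nM in this assay; compound 3 `N#Cc1c(NCc2ccccc2)sc2c1CCN(C(=O)c1ccccc1)C2` gives 2820 nM in this assay. Compound 3 thus stands second highest of the three numbers: its nearest neighbour is compound 2, reached by a 2.6-fold higher number from compound 2 to compound 3 (0.41 log units; beyond the scatter), and its furthest is compound 1, reached by a 15-fold lower number from compound 1 to compound 3 (1.19 log units; beyond the scatter); the remaining measured step, a 40-fold lower number from compound 1 to compound 2 (1.60 log units; beyond the scatter), removes the isopropyl. Compound 4 `N#Cc1c(NCc2ccccc2)sc2c1CCN(C(=O)c1ccc(F)cc1)C2` differs from compound 3 in one place: fluoro in place of hydrogen on an aromatic carbon, so that benzoyl becomes (4-fluorophenyl)carbonyl. Within the data shown here, none of the measured steps bears closely on this change; both steps ending at compound 3 exchange the whole group on the carbonyl carbon, and they give no guide to a single fluoro on the phenyl. For compound 4 a step in this assay no larger than the usual scatter is therefore expected, a 1.1-fold lower number from compound 3 to compound 4 (0.05 log units; within the scatter). Compound 4 is accordingly estimated at 2500 nM in this assay, with a range from 800 nM to 8000 nM.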

Compound 4, half-maximal inhibitory concentration: 600 nM
Compound 4: the middle estimate sits 4.2-fold (0.62 log units) above what was measured; measured number outside the range, below it.
By their numbers in this assay, from the lowest: compounds 4 and 2 (each within the scatter of the next); then compound 3; then compound 1.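

In this assay, a single fluoro on an aromatic carbon of the phenyl, para to a large group, proves enough on its own to shift the number (a 4.7-fold lower number from compound 3 to compound 4 (0.67 log units; beyond the scatter)), a modest step beyond the scatter, so this position responds to a change of just one heavy atom. The gain also removes the gap between the phenyl and pyrazole amides (a 1.8-fold lower number from compound 2 to compound 4 (0.26 log units; within the scatter)), which is within the scatter, while the 3-isopropyl-1H-pyrazol-5-yl amide remains far from the 4-fluorophenyl amide (a 72-fold lower number from compound 1 to compound 4 (1.86 log units; beyond the scatter)). Nothing given here explains the step from hydrogen to fluoro.

The compounds shown leave open whether chloro, methyl or methoxy at this place would give a similar step, and whether fluoro would do so elsewhere on the ring. They also leave open whether a methyl in place of the isopropyl on the pyrazole would be tolerated.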